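The compounds below may be only part of what the source reports. "The series", "measured", "known", "first", "only" and "open" are said of these compounds alone.

In a physicochemical assay for lipophilicity, at pH 7.4 (on this read-out higher numbers stand for higher lipophilicity and lower numbers for lower lipophilicity), compound 1 (`CC(C)Oc1ccc(-c2nnc(-n3cc4c(n3)CCN(CCC(=O)O)C4)s2)cc1Cl`) gives 3.26 and compound 3 (`Cc1c(-c2nnc(-c3ccc(OC(C)C)c(Cl)c3)s2)cnn1CCC(=O)O`) gives 3.16 with these two values lying within the scatter of each other. Compound 2 (`Cc1nc(C)c(-c2nnc(-c3ccc(OC(C)C)c(Cl)c3)s2)s1`) stands highest of the three at 7.76 and lies beyond the scatter from both. Compound 4 (`CC(C)Oc1ccc(-c2nnc(-c3ccnn3C)s2)cc1Cl`) has yet to be measured. It differs from compound 2 by having 1-methyl-1H-pyrazol-5-yl in place of 2,4-dimethyl-1,3-thiazol-5-yl on an aromatic carbon. Within the data shown here, no measured pair of compounds differs in one place, so the expectation rests on the structural change alone, and a moderate fall beyond the scatter in this assay is expected. An estimated step of a number 1.36 log units lower from compound 2 to compound 4 (beyond the scatter) is expected. For compound 4 the expected value is 6.4 (estimated range 5.6 to 7.2).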

Compound 4, distribution coefficient: 7.04
Estimate against measurement, compound 4: 0.64 log units below, within the range that was stated.
By their numbers in this assay, from the lowest: compounds 3 and 1 (each within the scatter of the next); then compound 4; then compound 2.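

Among these compounds, putting 1-methyl-1H-pyrazol-5-yl in place of 2,4-dimethyl-1,3-thiazol-5-yl on this aromatic carbon gives the first one-place comparison at this position in this assay and yields a number 0.72 log units lower from compound 2 to compound 4 (beyond the scatter). The two groups have the same counts of hydrogen-bond donors and acceptors and neither carries a net charge, so the step comes with those counts unchanged. Nothing available accounts for the size of this step. The compounds shown leave open how an amine or a phenyl ring on this aromatic carbon would read, and what a longer chain in place of the pyrazole methyl would do.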